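Sulfonyl substituent swap in the coumarin enaminone series

A few compounds are considered here, and "the series" means these few. Any claim that something is new, unique, unknown or untested is made for them only; others in the source may bear on it.

Among the measured compounds shown here, compound 2 `Cc1ccnc(NS(=O)(=O)c2ccc(N/C=C\C(=O)c3cc4ccccc4oc3=O)cc2)n1` gives 24500 nM in a functional assay on T47D cells (Homo sapiens) for cytotoxicity, read by sulforhodamine B assay, with a stated time of 48 h (a higher number here means a weaker inhibitor, a lower number a stronger inhibitor), the lowest of the two numbers so far. For the measured compounds named here, compound 1 `O=C(/C=C\Nc1ccc(S(=O)(=O)Nc2ncccn2)cc1)c1cc2ccccc2oc1=O` gives 75200 nM in this assay, and the only measured step, a 3.1-fold lower number from compound 1 to compound 2 (0.49 log units; beyond the scatter), concerns a methyl in place of hydrogen on an aromatic carbon. Compound 3 `Nc1ccc(S(=O)(=O)c2ccc(N/C=C\C(=O)c3cc4ccccc4oc3=O)cc2)cc1` is not yet measured. It differs from compound 2 by 4-aminophenyl in place of (4-methylpyrimidin-2-yl)amino on a sulfonyl sulfur. Going by the values given here, no measured step touches the whole group on the sulfonyl sulfur; the one step on record changes a substituent within that group rather than the group itself, so it gives no direct guidance on the size or direction of this change. With nothing to build on, no step beyond the scatter is expected, and compound 3 is estimated at 25000 nM in this assay, with a wide range from 7000 nM to 90000 nM. The expected step is a 1.0-fold higher number from compound 2 to compound 3 (0.01 log units; within the scatter).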

Compound 3, half-maximal inhibitory concentration: 91900 nM
For compound 3 the middle estimate is 3.7-fold (0.57 log units) below the measured one, and the stated range ends below it.
By their numbers in this assay, from the lowest: compound 2; then compounds 1 and 3 (each within the scatter of the next).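

On the sulfonyl sulfur, the whole group can be exchanged with a clear effect in this assay: 4-aminophenyl in place of (4-methylpyrimidin-2-yl)amino gives (a 3.8-fold higher number from compound 2 to compound 3 (0.57 log units; beyond the scatter)). The same entering group set against (pyrimidin-2-yl)amino gives (a 1.2-fold higher number from compound 1 to compound 3 (0.09 log units; within the scatter)), so the outcome depends on which group leaves, and among these three compounds only compound 2, the one carrying the methyl, stands apart from the other two by more than the scatter. No measurement at hand accounts for either step.

Open, from the compounds shown here alone, is whether a plain amine on the sulfonyl sulfur, or a phenyl lacking the amino group, would fall with compound 2 or with the other two compounds. Also open, going by these compounds, is whether an ethyl in place of the methyl would keep the number of compound 2.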